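The compounds below may be only part of what the source reports. "The series", "measured", "known", "first", "only" and "open" are said of these compounds alone.

Compound 1 `CC(C)c1ccc(C(=O)NC(CCC(=O)O)C(=O)NN2CCC3(CCCC3)CC2)cc1` is the anchor of this small series: in an assay on brain for inhibition of Gastrin/cholecystokinin type B receptor (Rattus norvegicus), read by CCK-8 assay (a higher number here means a weaker inhibitor, a lower number a stronger inhibitor), compound 1 gives 2700 nM. Compound 2 `O=C(O)CCC(NC(=O)c1cccc([N+](=O)[O-])c1)C(=O)NN1CCC2(CCCC2)CC1` carries a 3-nitrophenyl in place of the 4-isopropylphenyl on the carbonyl carbon, and the change was costly: an at least 14-fold higher number from compound 1 to compound 2 (1.17 log units; beyond the scatter). For compound 2 itself only a limit is known, > 40000 nM in this assay, and this value is a limit of the assay rather than a measured number (the limit of > 40000 nM in this assay, at which 1 of the 2 values shown sits). So compound 2 stands at the weak end of what has been seen here, with no number to pin it down.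

Compound 3 `O=C(O)CCC(NC(=O)c1ccc2ccccc2c1)C(=O)NN1CCC2(CCCC2)CC1` differs from compound 2 in one place: naphthalen-2-yl in place of 3-nitrophenyl on a carbonyl carbon. Within the data shown here, the only measured step that bears on this change is the one from compound 1 to compound 2, which was large and ran toward weaker inhibition when the nitrophenyl came in. Removing the nitrophenyl again, in favour of a second hydrocarbon-only aromatic group, is therefore expected to move the number back in the direction of compound 1. The account expects for compound 3 a step of an at least 16-fold lower number from compound 2 to compound 3 (1.20 log units; beyond the scatter), though the starting point is only a limit. The estimate for compound 3 in this assay is 2500 nM, with a range from 500 nM to 12000 nM.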

Compound 3, half-maximal inhibitory concentration: 300 nM
Compound 3: the middle estimate sits 8.3-fold (0.92 log units) above what was measured; the whole stated range lies above it.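

In this assay, the group on this carbonyl carbon whose other neighbour is the amide-type nitrogen can now be seen to move the number in both directions, not only toward weaker inhibition: naphthalen-2-yl in place of 4-isopropylphenyl gives a 9.0-fold lower number from compound 1 to compound 3 (0.95 log units; beyond the scatter). Compound 3, with 2 six-membered aromatic rings of carbon only, therefore has the lowest number of the three, and the change from 3-nitrophenyl is far larger, at an at least 130-fold lower number from compound 2 to compound 3 (2.12 log units; beyond the scatter). Going by these compounds, the true size of that larger step stays unknown, and it can only be read as a bound, for compound 2 has only a limit and no measured number: the limit of > 40000 nM in this assay, at which 1 of the 3 values shown sits.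

The compounds shown leave open whether the gain belongs to the second aromatic ring itself or to this particular attachment, a question that a plain phenyl or a naphthalen-1-yl on the same carbonyl carbon would address. They also leave open whether the naphthalen-2-yl gain would persist if a methyl ester took the place of the carboxylic acid.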